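A primary amine gives way to a hydroxyl

The source may hold more compounds than are shown below. What is called first, only, known or untested is meant among the compounds shown, and "the series" means these compounds.

Compound 1 `Cc1ccc(CNC(=O)C(CCN)N(C)CCC=C(c2sccc2C)c2sccc2C)cc1` stands highest of the three compounds measured in a physicochemical assay for lipophilicity, read by HPLC (a higher number here means a more lipophilic compound, a lower number a more polar compound), where compound 1 gives 6.61. Compound 2 `Cc1ccsc1C(=CCCN(C)C(CCN)C(=O)NCc1ccccc1Cl)c1sccc1C` gives 6.11 and compound 3 `Cc1ccsc1C(=CCCN(C)C(CCN)C(=O)NCc1ccc(Cl)cc1)c1sccc1C` gives 5.85; the steps of a number 0.50 log units lower from compound 1 to compound 2 (beyond the scatter) and a number 0.76 log units lower from compound 1 to compound 3 (beyond the scatter) lie beyond the scatter, while the step of a number 0.26 log units lower from compound 2 to compound 3 (within the scatter) does not. Compound 4 `Cc1ccc(CNC(=O)C(CCO)N(C)CCC=C(c2sccc2C)c2sccc2C)cc1` differs from compound 1 in one place: hydroxy in place of amino on a saturated chain carbon, three bonds along the chain from an amine nitrogen and a carbonyl carbon. Each measured step concerns the aryl group on the amide side, so none of them bears on this change at the chain end. With no measured guide, the estimate for compound 4 in this assay is 7.3, with a range from 6.6 to 8, which would mean an expected step of a number 0.69 log units higher from compound 1 to compound 4 (beyond the scatter).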

Compound 4, partition coefficient: 6.2
Beside the measured number, compound 4's estimate is 1.10 log units above it; the measured number lies below the stated range.
By their numbers in this assay, from the lowest: compounds 3, 2 and 4 (each within the scatter of the next, the first and the last beyond it); then compound 1.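

At the chain end, hydroxy in place of amino moves the reading in this assay, giving a number 0.41 log units lower from compound 1 to compound 4 (beyond the scatter). Among these compounds, the earlier steps all concerned the aryl group on the amide side, so this is the first sign that the chain end also affects this read-out. Nothing shown accounts for the direction of this step.

From the compounds shown here alone, it remains open whether a methoxy group, a carboxylic acid or a longer chain at this position would shift the number further. Whether the same exchange gives a similar step on compound 2 or compound 3 is also unresolved.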